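Replacing the Isopropylcarbamoyl Group with Acetyl

The compounds below may be only part of what the source reports. "The series", "measured", "known", "first", "only" and "open" are said of these compounds alone.

Of the compounds shown here, three have been measured in a functional assay for inhibition of nuclear factor NF-kappa-B complex (Homo sapiens); a higher number here means a weaker inhibitor, a lower number a stronger inhibitor.
Compound 1, `CCOCC1=Cc2ccc(OC)cc2OC1c1cc(OC)c(OC)c(OC)c1`: 21300 nM
Compound 2, `COC(=O)C1=Cc2ccc(OC)cc2OC1c1cc(OC)c(OC)c(OC)c1`: 13800 nM
Compound 3, `COc1ccc2c(c1)OC(c1cc(OC)c(OC)c(OC)c1)C(C(=O)NC(C)C)=C2`: > 50000 nM, a limit of this assay rather than a number

Compound 3 stands at the limit of > 50000 nM in this assay, at which 1 of the 3 values shown sits, the weakest reading shown. The unmeasured compound 4, `COc1ccc2c(c1)OC(c1cc(OC)c(OC)c(OC)c1)C(C(C)=O)=C2`, differs from it by methyl in place of isopropylamino on a carbonyl carbon. Of the measured steps, an at least 3.6-fold higher number from compound 2 to compound 3 (0.55 log units; beyond the scatter) is the one most akin to this change, as it introduced the isopropylamino group now removed; a 1.5-fold lower number from compound 1 to compound 2 (0.19 log units; within the scatter) shows that the other substituents on that double-bonded ring carbon differ little. Compound 4 is therefore expected to return into the range of compounds 1 and 2, a modest step down estimated as an at least 2.5-fold lower number from compound 3 to compound 4 (0.39 log units; beyond the scatter). In this assay compound 4 is estimated at 20000 nM, between 8000 nM and 55000 nM.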

Compound 4, half-maximal inhibitory concentration: 14100 nM
Beside the measured number, compound 4's estimate is 1.4-fold (0.15 log units) above it; the range from low to high includes it.
By their numbers in this assay, from the lowest: compounds 2, 4 and 1 (each within the scatter of the next). At a limit, above all of these: compound 3.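

In this assay, methyl in place of isopropylamino on a carbonyl carbon gives an at least 3.5-fold lower number from compound 3 to compound 4 (0.54 log units; beyond the scatter), which shows that a second group without the isopropylamino recovers the activity, not the ester alone. That step is only a bound, since the reading of compound 3 is a limit of the assay: the limit of > 50000 nM in this assay, at which 1 of the 4 values shown sits. Acetyl also sits with the other two groups, with a 1.0-fold higher number from compound 2 to compound 4 (0.01 log units; within the scatter) and a 1.5-fold lower number from compound 1 to compound 4 (0.18 log units; within the scatter) as its readings, so only the isopropylcarbamoyl compound stands apart.

Going by these compounds, it remains open whether a carboxylic acid, a primary amide or a dimethylamide on that ring carbon would stay with compounds 1, 2 and 4 or fall with compound 3.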